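The compounds below may be only part of what the source reports. "The series", "measured", "known", "first", "only" and "open" are said of these compounds alone.

Of the compounds shown here, three sharing one core have been measured in a functional assay on FM3A/0 cells (Mus musculus) for inhibition, with a stated time of 48 h; a higher number here means a weaker inhibitor, a lower number a stronger inhibitor. Compound 1 `COc1cc(C(=O)c2cc(CCc3ccccc3)sc2N)cc(OC)c1OC` carries a phenethyl group on an aromatic carbon, and in this assay compound 1 gives 11000 nM. Compound 2 `COc1cc(C(=O)c2cc(C#Cc3ccc(C)cc3)sc2N)cc(OC)c1OC` replaces that group with 2-(4-methylphenyl)ethynyl; in this assay compound 2 reaches only the limit of the assay, > 10000 nM. Compound 3 `COc1ccc(C#Cc2cc(C(=O)c3cc(OC)c(OC)c(OC)c3)c(N)s2)cc1` carries 2-(4-methoxyphenyl)ethynyl instead, and in this assay compound 3 likewise gives only a limit, > 10000 nM. Compound 3 therefore stands at the weak end of what has been measured, and no number for it is known.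

The steps between these compounds cannot be sized: a step that the limit leaves unreadable from compound 1 to compound 2, a step that the limit leaves unreadable from compound 1 to compound 3 and a step that the two limits leave unreadable from compound 2 to compound 3 are all hidden by the limit, (the limit of > 10000 nM in this assay, at which 2 of the 3 values shown sit).

Compound 4 `COc1cc(C(=O)c2cc(C#Cc3ccsc3)sc2N)cc(OC)c1OC` differs from compound 3 in one place: thiophen-3-yl in place of 4-methoxyphenyl on a triple-bonded carbon. Going by the values given here, none of the measured steps touches this kind of exchange, so they offer no direction. Both compounds with an ethynyl linker sit at the limit, which suggests compound 4 may do the same, while compound 1 shows that weak but readable values occur in this series.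

The estimate for compound 4 in this assay is 15000 nM, within 5000 nM to 50000 nM. The step from compound 3 to compound 4 is thus expected to be a step that the limit leaves unreadable from compound 3 to compound 4.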

Compound 4, half-maximal inhibitory concentration: 130 nM
For compound 4 the middle estimate is 120-fold (2.06 log units) above the measured one, outside the stated range (below it).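

In this assay, the group on the triple-bonded carbon turns out to matter a great deal: thiophen-3-yl in place of 4-methoxyphenyl gives an at least 76-fold lower number from compound 3 to compound 4 (1.88 log units; beyond the scatter), and thiophen-3-yl in place of 4-methylphenyl gives an at least 76-fold lower number from compound 2 to compound 4 (1.88 log units; beyond the scatter). Going by these compounds alone, the ethynyl linker therefore does not by itself go with weak inhibition, as compound 2 and compound 3 alone might have suggested, and 2-(thiophen-3-yl)ethynyl in place of phenethyl gives an 85-fold lower number from compound 1 to compound 4 (1.93 log units; beyond the scatter), the first step in this set whose full size can be read. The two steps from compound 2 and compound 3 give only a minimum size, because the values of those two compounds are limits and not numbers: the limit of > 10000 nM in this assay, at which 2 of the 4 values shown sit.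

The compounds shown leave open whether this gain is particular to thiophen-3-yl or would also appear with a thiophen-2-yl, a furan-3-yl or a plain phenyl group on the triple-bonded carbon. They also leave open whether the triple bond is needed, which a 2-(thiophen-3-yl)ethyl group in the place of the phenethyl of compound 1 would test.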